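The source may hold more compounds than are shown below. What is called first, only, known or untested is meant among the compounds shown, and "the series" means these compounds.

Compounds measured for cytotoxicity in an ADME assay on HEL cells (Homo sapiens) for cytotoxicity, with a stated time of 3 days; a higher number here means that more compound is tolerated, a lower number that less compound is tolerated:

compound 1 `CCC1(Cc2ccccc2)OS(=O)(=O)C=C1OCc1ccc(F)cc1`: >= 50000 nM
compound 2 `CCC1(Cc2ccccc2)OS(=O)(=O)C=C1OCc1ccc(Cl)cc1`: >= 50000 nM

Both values in this assay are limits of the assay, not numbers. Compound 1 reaches only a limit at >= 50000 nM. Compound 2 likewise reaches only a limit at >= 50000 nM. Within the data shown here, the single measured step, chloro in place of fluoro on an aromatic carbon, reads as a step that the two limits leave unreadable from compound 1 to compound 2; its size is not readable, since both ends are limits. Compound 2 therefore stands at the limit shared by everything measured so far: the limit of >= 50000 nM in this assay, at which 2 of the 2 values shown sit.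

Compound 3 `CCC1(Cc2ccccc2)OS(=O)(=O)C=C1OCc1ccc([N+](=O)[O-])cc1` remains to be measured in this assay. Its change from compound 2 is nitro in place of chloro on an aromatic carbon. Among the measured compounds shown here, no measured step bears on this change with a readable size; the step from compound 1 to compound 2 sits between two limits and carries no number. The expectation rests only on the fact that both measured compounds sit at the limit. For compound 3 the expected step is a number no higher from compound 2 to compound 3 (the limit leaves the size open), that is, no step beyond the scatter. The estimate for compound 3 is 50000 nM, with a range from 20000 nM to 120000 nM, most likely again reported as a limit.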

Compound 3, minimum cytotoxic concentration: >= 80000 nM
Compound 3: no number, only a limit; the forecaster's own chance of this, stated with the estimate: 75%; at least 1.6-fold (0.20 log units) between middle value and limit.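

In this assay compound 3 reaches only a limit, >= 80000 nM. Among these compounds, compound 1, compound 2 and compound 3 all stand as limits, so no step among them can be read. The compounds shown leave open the concentration at which any of the three becomes cytotoxic, and whether changing fluoro, chloro or nitro on the aromatic carbon alters tolerance at all.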